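The compounds below may be only part of what the source reports. "The series", "measured", "known", "first", "only" and "open" are said of these compounds alone.

Measured so far in a functional assay on HeLa cells (Homo sapiens) for cytotoxicity, read by MTT assay, with a stated time of 24 h; a lower number here means a stronger inhibitor, a higher number a weaker inhibitor:

compound 1, `C=CC1=C(C(=O)NCc2ccc(C)cc2)C(c2ccc(F)cc2)OC1`: > 100000 nM (a limit of the assay, not a number)
compound 2, `C=CC1=C(C(=O)NCCC)C(c2ccc(Cl)c(Cl)c2)OC1`: > 100000 nM (likewise a limit, not a number)

Compound 2 therefore stands only at the limit of > 100000 nM in this assay, at which 2 of the 2 values shown sit; where it lies beyond that is not known.

Compound 3, `C=CC1=C(C(=O)NC(C)(C)C)C(c2ccc(Cl)c(Cl)c2)OC1`, differs from compound 2 by tert-butyl in place of propyl on an amide-type nitrogen. Among the measured compounds shown here, no measured pair carries this change, so nothing here sets a size for it. With both known values sitting at the limit, no movement beyond the usual scatter is expected, and the step that the limit leaves unreadable from compound 2 to compound 3 is itself only an estimate. Compound 3 is expected to give about 200000 nM in this assay, within 60000 nM to 600000 nM, most likely again reported as a limit.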

Compound 3, half-maximal inhibitory concentration: > 100000 nM
Compound 3: a limit, no number (the forecaster's own chance of this, stated with the estimate: 85%); the middle value does not contradict the limit.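

In this assay, no step can be read between compound 2 and compound 3, which carry propyl and tert-butyl on the amide-type nitrogen; both stand only at a limit of the assay: the limit of > 100000 nM in this assay, at which 3 of the 3 values shown sit.

The compounds shown leave open how far beyond that limit each one lies.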